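The compounds below may be only part of what the source reports. "The series", "measured", "known", "first", "only" and "open" are said of these compounds alone.

Working notes on the series.

Two members have been run in a physicochemical assay for lipophilicity; on this read-out lower numbers stand for lower lipophilicity and higher numbers for higher lipophilicity. Compound 1 `C=CCOC(=O)/C=C(C)/C=C/CC(C)CCCC(C)(C)OC` carries an allyloxycarbonyl end on the shared core; in this assay compound 1 gives 5.53. Within the data shown here, compound 2 `CCN(CC)C(=O)/C=C(C)/C=C/CC(C)CCCC(C)C` differs from compound 1 in more than one place, so no single step connects them; in this assay compound 2 gives 6.02. Compound 1 thus holds the lower of the two numbers, and the gap up to compound 2 lies beyond the usual scatter.

The next member, compound 3 `CCC(C)C(=O)/C=C(C)/C=C/CC(C)CCCC(C)(C)OC`, is not yet measured. It stands one change away from compound 1: sec-butyl in place of allyloxy on a carbonyl carbon. An oxygen atom and a hydrogen-bond acceptor leave and four carbons enter, so the step is expected to go upward rather than downward or to stay flat, by an amount likely beyond the scatter but modest. The expected step from compound 1 to compound 3 is a number 0.37 log units higher from compound 1 to compound 3 (beyond the scatter). On that basis the estimate for compound 3 in this assay is 5.9, with a range from 5.4 to 6.4.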

Compound 3, partition coefficient: 6.02
The estimate for compound 3 lay 0.12 log units below the measured number; the measured number falls inside the stated range.
By their numbers in this assay, from the lowest: compound 1; then compounds 2 and 3 (each within the scatter of the next).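

This gives the series its first single-place step: in this assay, sec-butyl in place of allyloxy on a carbonyl carbon gives a number 0.49 log units higher from compound 1 to compound 3 (beyond the scatter), so this position responds to this change on this read-out. The two groups each hold 4 heavy atoms, so the step arises without a change in that count, while the swap of allyloxycarbonyl to (sec-butyl)carbonyl exchanges one oxygen for one carbon and removes a hydrogen-bond acceptor and a double bond outside aromatic rings. The data offer nothing that assigns the step to any one of these differences.

Among these compounds, the reading rests on one pair on the shared core, and compound 2 differs from both other compounds in more than one place, so it adds no step at this position. As far as these compounds go, how a straight n-butyl chain or the hydroxy group of a carboxylic acid on the same carbonyl carbon would read remains open, as does whether the step would keep its size on a different core.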